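From Cyclopropyl to Ethyl at a Chemokine Receptor

A few compounds are considered here, and "the series" means these few. Any claim that something is new, unique, unknown or untested is made for them only; others in the source may bear on it.

Of the compounds shown here, three sharing one core have been tested in a functional assay on CCRF-CEM cells for agonist activity at C-X-C chemokine receptor type 4 (Homo sapiens), read by calcium flux, with a stated time of 25 min; on this read-out higher numbers stand for an effect only at larger amounts of compound and lower numbers for an effect already at smaller amounts. Compound 1 `c1cnc2c(c1)CCC[C@@H]2N(CC1CC1)C[C@H]1Cc2c(cccc2N2CCNCC2)CN1` gives > 30000 nM in this assay, which is a limit of the assay rather than a number. Compound 2 `Cc1cnc(CN(C)C[C@H]2Cc3c(cccc3N3CCNCC3)CN2)c(C)c1` gives > 30000 nM in this assay, again a limit. Compound 3 `CN1CCN(c2cccc3c2C[C@H](CN(C)[C@H]2CCCc4cccnc42)NC3)CC1` gives > 30000 nM in this assay, also a limit. Because all three sit at the limit of > 30000 nM in this assay, at which 3 of the 3 values shown sit, none of them can be set apart from the others, and compound 1 stands exactly where its two companions stand: at the edge of what this assay can report.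

Compound 4 `CCCN(C[C@H]1Cc2c(cccc2N2CCNCC2)CN1)[C@H]1CCCc2cccnc21` has not yet been measured. It differs from compound 1 in one place: ethyl in place of cyclopropyl on a saturated chain carbon bound to an amine nitrogen, so that ethyl takes the place of cyclopropyl on a saturated chain carbon bound to an amine nitrogen. Within the data shown here, no measured pair in this set shows a change of this kind, so no step of known size is available to guide the expectation. Because compound 1 sits at the limit of > 30000 nM in this assay, at which 3 of the 3 values shown sit, the expected step is a number no higher from compound 1 to compound 4 (the limit leaves the size open), which means none beyond the scatter. Compound 4 is therefore estimated to give 30000 nM in this assay, within a range from 10000 nM to 100000 nM, and most probably again as a limit rather than a number.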

Compound 4, half-maximal effective concentration: > 30000 nM
Compound 4: a limit, no number; the forecaster's own chance of this, stated with the estimate: 85%; the middle value lies on the limit itself.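

In this assay compound 4 gives > 30000 nM, a limit and not a number. Among these compounds, compound 1 also stands at a limit, so no step between compound 1 and compound 4 can be read: the limit of > 30000 nM in this assay, at which 4 of the 4 values shown sit. The compounds shown leave open whether ethyl in place of cyclopropyl changes the effect at all, and at what amount any of them would act.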